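Fluoro in place of trifluoromethoxy: a second instance

A few compounds are considered here, and "the series" means these few. Any claim that something is new, unique, unknown or untested is made for them only; others in the source may bear on it.

Compound 1 `CCC1=C(O)c2c(oc(-c3ccc(OC(F)(F)F)cc3)cc2=O)C(CC)(CC)C1=O` carries a trifluoromethoxy group on the aryl ring, and in a functional assay on KBVIN cells (Homo sapiens) for antiproliferative activity, read by sulforhodamine B assay, with a stated time of 3 days (a lower number here means that less compound is needed, a higher number that more compound is needed for the effect), compound 1 gives 9.95 uM. Compound 2 `CCC1=C(O)c2c(oc(-c3ccc(F)cc3)cc2=O)C(CC)(CC)C1=O` differs from it by fluoro in place of trifluoromethoxy on an aromatic carbon; in this assay compound 2 gives 1.85 uM, which amounts to a 5.4-fold lower number from compound 1 to compound 2 (0.73 log units; beyond the scatter).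

Compound 3 `CCC1=C(O)c2c(oc(-c3cccc(OC(F)(F)F)c3)cc2=O)C(CC)(CC)C1=O` is built from the same atoms as compound 1 joined differently; the difference between the two cores is not broken down here. In this assay, among the compounds with values here, compound 3 gives 9.95 uM, level with compound 1 as far as the figures go and within the scatter of it, so the two together stand as the highest numbers of the three measured so far.

Compound 4 `CCC1=C(O)c2c(oc(-c3cccc(F)c3)cc2=O)C(CC)(CC)C1=O` stands to compound 3 as compound 2 stands to compound 1: fluoro in place of trifluoromethoxy on an aromatic carbon. The surroundings are not identical, though. In compound 1 the group that leaves sits para to a large group, in compound 3 it sits meta to a large group, so this is the same kind of change rather than the same change. The expectation therefore rests on a single measured instance of the swap. Compound 4 is expected to give 2.5 uM, with a likely range from 1 uM to 6 uM. The estimated step is a 4.0-fold lower number from compound 3 to compound 4 (0.60 log units; beyond the scatter), set a little short of a 5.4-fold lower number from compound 1 to compound 2 (0.73 log units; beyond the scatter) to allow for the different place of the swap.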

Compound 4, concentration for half-maximal effect: 3.09 uM
The estimate for compound 4 lay 1.2-fold (0.09 log units) below the measured number; the range from low to high includes it.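

Fluoro in place of trifluoromethoxy gives a lower number on both cores in this assay, and the two steps do not differ by more than the scatter: the same change on two cores in this assay, a 5.4-fold lower number (0.73 log units; beyond the scatter) from compound 1 to compound 2 and a 3.2-fold lower number (0.51 log units; beyond the scatter) from compound 3 to compound 4, 1.7-fold (0.22 log units) apart, within the scatter of two such steps.
The second instance, a 3.2-fold lower number from compound 3 to compound 4 (0.51 log units; beyond the scatter), shows that the change has carried from the core of compound 1 to the core of compound 3 in direction and, as far as two steps can tell, in size. This does not make it a rule for the series: the evidence is one pair of steps on two closely related cores, in one assay, and the fluoro compounds themselves are not separated, since a 1.7-fold higher number from compound 2 to compound 4 (0.22 log units; within the scatter), with 3-fluorophenyl in place of 4-fluorophenyl, cannot be told from repeat variation.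

The compounds shown leave open whether the step would hold if the group leaving or entering on the aromatic ring were something else, such as an amine or a carboxylic acid. They also leave open how the step would behave on a core with a longer chain in place of the ethyl groups, and in cells other than those of this assay.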